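Three Aryl Swaps on One Core, All Beyond Reach

The source may hold more compounds than are shown below. What is called first, only, known or untested is meant among the compounds shown, and "the series" means these compounds.

Three close relatives share one core and differ only in the aryl group on an aromatic nitrogen of the five-membered aromatic ring with 3 nitrogen. Compound 1 `COc1ccccc1-n1nncc1CN1C(=O)C2(C(C#N)=C(N)Oc3c2c2nc4ccccc4nc2c2ccccc32)c2ccccc21` carries a 2-methoxyphenyl there. In a functional assay on MCF7 cells (Homo sapiens) for antiproliferative activity, read by MTT assay, with a stated time of 48 h (a lower number here means a stronger inhibitor, a higher number a weaker inhibitor), compound 1 gives > 50000 nM, which is a limit of the assay and not a number. Compound 2 `N#CC1=C(N)Oc2c(c3nc4ccccc4nc3c3ccccc23)C12C(=O)N(Cc1cnnn1-c1ccc(S(N)(=O)=O)cc1)c1ccccc12` carries a 4-sulfamoylphenyl instead. In this assay compound 2 gives > 50000 nM, again a limit. Compound 3 `Cc1ccc(-n2nncc2CN2C(=O)C3(C(C#N)=C(N)Oc4c3c3nc5ccccc5nc3c3ccccc43)c3ccccc32)cc1Cl` carries a 3-chloro-4-methylphenyl. In this assay compound 3 gives > 50000 nM, also a limit. Because (the limit of > 50000 nM in this assay, at which 3 of the 3 values shown sit), the steps a step that the two limits leave unreadable from compound 1 to compound 2 and a step that the two limits leave unreadable from compound 1 to compound 3 cannot be sized, and a step that the two limits leave unreadable from compound 2 to compound 3 cannot either.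

Compound 4 `N#CC1=C(N)Oc2c(c3nc4ccccc4nc3c3ccccc23)C12C(=O)N(Cc1cnnn1-c1ccc(F)c(Cl)c1)c1ccccc12` is yet to be measured. It differs from compound 1 by 3-chloro-4-fluorophenyl in place of 2-methoxyphenyl on an aromatic nitrogen. The measured step nearest in kind is a step that the two limits leave unreadable from compound 1 to compound 3, whose size is unreadable. With every measured value sitting at the limit, compound 4 is expected to sit there as well. The estimate for compound 4 is 60000 nM, spanning 25000 nM to 200000 nM. The step that the limit leaves unreadable from compound 1 to compound 4 is thus expected to stay unreadable too.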

Compound 4, half-maximal inhibitory concentration: > 50000 nM
Compound 4: no number, only a limit; the forecaster's own chance of this, stated with the estimate: 85%; the middle value does not contradict the limit.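

Compound 4 gives only a limit and not a number in this assay, so its steps to compound 1, compound 2 and compound 3 cannot be read: the limit of > 50000 nM in this assay, at which 4 of the 4 values shown sit.

The compounds shown leave open whether the aryl group on this shared core changes activity at all in this assay.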